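A few compounds are considered here, and "the series" means these few. Any claim that something is new, unique, unknown or untested is made for them only; others in the source may bear on it.

Compound 1 `Cc1ccc(C(=O)Nc2cc(-c3ccccc3)nn2-c2ccccc2)cc1`: 780 nM
Compound 2 `N#Cc1cccc(-n2nc(-c3ccccc3)cc2NC(=O)c2ccccc2)c1`: > 10000 nM (a limit)

Going by the values given here, in an assay on HEK293 cells for displacement of a labelled ligand from metabotropic glutamate receptor 5 (Rattus norvegicus) (on this read-out higher numbers stand for weaker inhibition and lower numbers for stronger inhibition), compound 1 gives 780 nM, and this is the only number among the two measured compounds. For compound 2 the result is a limit of the assay, > 10000 nM. Of the two results, one sits at the limit of > 10000 nM in this assay, at which 1 of the 2 values shown sits. Compound 3 `O=C(Nc1cc(-c2ccccc2)nn1-c1ccccc1)c1ccncc1` has not yet been measured. It differs from compound 1 in one place: pyridin-4-yl in place of 4-methylphenyl on a carbonyl carbon. Among the compounds with values here, no step between two measured compounds is available to set the size of this change, so the expectation rests on compound 1 alone. With compound 1 at 780 nM as the only anchor, a loss of affinity is expected, with a step of a 3.2-fold higher number from compound 1 to compound 3 (0.51 log units; beyond the scatter) that reaches beyond the scatter. Compound 3 is therefore estimated at 2500 nM, in a range from 600 nM to 10000 nM, and it may be reported only as a limit.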

Compound 3, inhibition constant: > 10000 nM
Compound 3 gave a limit, no number; the forecaster's own chance of this, stated with the estimate: 30%; at least 4.0-fold (0.60 log units) between middle value and limit.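

In this assay, going by these compounds alone, the change from 4-methylphenyl to pyridin-4-yl on a carbonyl carbon supplies the first step that can be read between two measured compounds: an at least 12-fold higher number from compound 1 to compound 3 (1.10 log units; beyond the scatter). From the compounds shown here alone, compound 3 gives > 10000 nM, which is a limit and not a number, so the full size of this step stays unknown. Within the data shown here, the result shows that affinity depends on which six-membered aromatic ring sits at this place, and it leaves compound 1 as the only compound with a number: the limit of > 10000 nM in this assay, at which 2 of the 3 values shown sit.

The change both removes the methyl group and brings in a ring nitrogen, and the compounds shown do not separate these two parts. They also leave open how a plain phenyl, or a 4-methoxyphenyl or 4-chlorophenyl group, would read at this place on the core of compound 1.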